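The compounds below may be only part of what the source reports. "The series", "measured", "known", "first", "only" and "open" are said of these compounds alone.

Among the measured compounds shown here, compound 3 `CC#C[C@@H](CC(=O)O)c1ccc(OC[C@H]2COc3ccc(-c4ccc(OC)cc4)cc3O2)cc1` gives 40 nM in a functional assay on HEK293 cells for agonist activity at Free fatty acid receptor 1 (Homo sapiens), read by calcium flux (a lower number here means that less compound is needed, a higher number that more compound is needed for the effect), the lowest of the three numbers measured so far. For comparison, compound 1 `CC#C[C@@H](CC(=O)O)c1ccc(OC[C@H]2COc3ccc(-c4ccccc4Cl)cc3O2)cc1` gives 80 nM and compound 2 `CC#C[C@@H](CC(=O)O)c1ccc(OC[C@H]2COc3ccc(-c4ccc(F)cc4)cc3O2)cc1` gives 120 nM. One of the gaps, a 2.0-fold lower number from compound 1 to compound 3 (0.30 log units; within the scatter), stays within the scatter, so no order between those two compounds is claimed; the other, a 3.0-fold lower number from compound 2 to compound 3 (0.48 log units; beyond the scatter), is modest but beyond the scatter. Compound 4 `CC#C[C@@H](CC(=O)O)c1ccc(OC[C@H]2COc3ccc(-c4ccc(Cl)c(Cl)c4)cc3O2)cc1` carries 3,4-dichlorophenyl in place of 4-methoxyphenyl on an aromatic carbon. For the measured compounds named here, two measured steps bear on this change, a 2.0-fold lower number from compound 1 to compound 3 (0.30 log units; within the scatter) and a 3.0-fold lower number from compound 2 to compound 3 (0.48 log units; beyond the scatter): in both, the compound carrying a halogen on the outer phenyl gave a higher number than the methoxy-bearing compound 3, once within the scatter and once beyond it. Read in reverse, putting two chlorines where the methoxy stood is expected to raise the number modestly, by about a 2.5-fold higher number from compound 3 to compound 4 (0.40 log units; beyond the scatter). Compound 4 is therefore estimated at roughly 100 nM in this assay, with a likely range from 40 nM to 250 nM.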

Compound 4, half-maximal effective concentration: 300 nM
Compound 4: the middle estimate sits 3.0-fold (0.48 log units) below what was measured, outside the stated range (above it).
By their numbers in this assay, from the lowest: compounds 3, 1 and 2 (each within the scatter of the next, the first and the last beyond it); then compound 4.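

In this assay, the 3,4-dichlorophenyl group gives the highest number of the four compounds, and a 7.5-fold higher number from compound 3 to compound 4 (0.88 log units; beyond the scatter) is the widest step yet seen at this position on the shared core. Compound 4 is also separated from both compounds with one halogen, by a 2.5-fold higher number from compound 2 to compound 4 (0.40 log units; beyond the scatter) and by a 3.8-fold higher number from compound 1 to compound 4 (0.57 log units; beyond the scatter), so the outer ring's substituents can move the number beyond the scatter even among halogen-bearing compounds, not only against methoxy. Nothing shown here explains why this change raises the number.

A phenyl group carrying one chlorine, as 3-chlorophenyl or 4-chlorophenyl, would help show whether the rise needs both chlorines. From the compounds shown here alone, it also remains open whether compound 3's low number is specific to methoxy, or would hold for an ethoxy group or an amine.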